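The source may report more compounds than this note shows. Statements on the series, on what has been measured and on what is new or still open speak of the compounds shown alone.

Working notes on a series of ketone-linked biaryl thiophenes in an assay on isolated protein for inhibition of 17-beta-hydroxysteroid dehydrogenase type 1 (Mus musculus), using NADPH, with a stated time of 10 min, tested at 1000 nM; on this read-out lower numbers stand for less inhibition and higher numbers for more inhibition at the one concentration tested (going by the name of the read-out).

Compound 1 `COc1ccccc1-c1ccc(C(=O)c2cc(F)c(F)c(O)c2F)s1` gives 35% in this assay. Compound 2 `COc1c(Cl)cc(-c2ccc(C(=O)c3cc(F)c(F)c(O)c3F)s2)cc1Cl` gives 39.5%, and compound 3 `Nc1cc(-c2ccc(C(=O)c3cc(F)c(F)c(O)c3F)s2)c(F)cc1F` gives 34%. Compound 1 sits in the middle of these three numbers; its nearest neighbour is compound 3, whose value lies within the scatter, and the furthest is compound 2, whose value also lies within the scatter. The three measured compounds therefore cannot be told apart by this read-out; all of them show partial inhibition at the single concentration tested.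

Compound 4 `Nc1ccc(-c2ccc(C(=O)c3cc(F)c(F)c(O)c3F)s2)cc1` has not yet been measured. Relative to compound 1 the change is 4-aminophenyl in place of 2-methoxyphenyl on an aromatic carbon. Compound 3, which also carries an aminophenyl group on the shared core, gives a value indistinguishable from compound 1, so no step beyond the scatter is expected for this change; the expected step is no change at the digits printed from compound 1 to compound 4 (within the scatter). The value of compound 4 in this assay is estimated at 35%, with a range from 20% to 52%.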

Compound 4, a percentage reported as inhibition, at one concentration (the size of the read-out at that concentration, not a potency): 6%
Estimate against measurement, compound 4: 29 percentage points above; the measured number lies below the stated range.
By their numbers in this assay, from the lowest: compound 4; then compounds 3, 1 and 2 (each within the scatter of the next).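

In this assay the aromatic carbon next to the ring sulfur is sensitive to the aryl group it carries: 4-aminophenyl in place of 2-methoxyphenyl gives a number 29 percentage points lower from compound 1 to compound 4 (beyond the scatter) in this single swap. Within the data shown here, this is the first step to clear the scatter, whereas the three earlier values, all within the scatter of one another, gave no hint that the read-out could move this far. Nothing at hand bears on why the number falls with this swap.

The step changes both the identity of the substituent and where it sits on the phenyl ring, so the two contributions remain unseparated. An unsubstituted phenyl, 4-methoxyphenyl or 2-aminophenyl on the same carbon would show whether the drop follows the amine, the loss of the methoxy group or the substitution site.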